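Swapping the Cap Substituent on a Hydroxamate Sulfonamide

A few compounds are considered here, and "the series" means these few. Any claim that something is new, unique, unknown or untested is made for them only; others in the source may bear on it.

Compound 1: `O=C(CCCCCCCC(=O)c1ccc(-c2ccc(Br)cc2)cc1)NO` — in an assay on isolated protein for inhibition of histone deacetylase 8 (Homo sapiens) (a higher number here means a weaker inhibitor, a lower number a stronger inhibitor), compound 1 gives 2 nM.
Compound 2: `CC(C)(C)c1ccc(CS(=O)(=O)Nc2ccc(/C=C\C(=O)NO)cc2)cc1` — in this assay compound 2 gives 100 nM.

Compound 2 stands at the higher of the two numbers measured, a weaker inhibitor than compound 1, and the gap between the two lies beyond the usual scatter. The two compounds share only the hydroxamic acid end; their cores differ throughout, so nothing is known about what any single change does.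

Compound 3, `COc1ccc(CS(=O)(=O)Nc2ccc(/C=C\C(=O)NO)cc2)cc1`, differs from compound 2 in one place: methoxy in place of tert-butyl on an aromatic carbon. Within the data shown here, with no step between measured compounds to lean on, the expected change from compound 2 to compound 3 is modest, perhaps a slight shift to a higher number, and quite possibly within the scatter; this expectation is written as a 1.5-fold higher number from compound 2 to compound 3 (0.18 log units; within the scatter). For compound 3 the estimate is 150 nM, with a range from 40 nM to 600 nM.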

Compound 3, half-maximal inhibitory concentration: 60 nM
For compound 3 the middle estimate is 2.5-fold (0.40 log units) above the measured one; measured number inside the range.
By their numbers in this assay, from the lowest: compound 1; then compounds 3 and 2 (each within the scatter of the next).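

In this assay, among these compounds, methoxy in place of tert-butyl on an aromatic carbon para to a large group gives a 1.7-fold lower number from compound 2 to compound 3 (0.22 log units; within the scatter) and provides the only single-change reading in this set. At this position, a group of 4 heavy atoms with 0 hydrogen-bond acceptors can thus give way to one of 2 heavy atoms with 1 hydrogen-bond acceptor without the number leaving the scatter, so this pair shows no measurable preference between the two groups. Nothing at hand bears on why the two groups read alike.

As far as these compounds go, whether an amine, a carboxylic acid or a longer chain at this position would also stay within the scatter remains open. Also open, from the compounds shown here alone, is whether the exchange of tert-butyl for methoxy would read the same way on a different core.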